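The source may hold more compounds than are shown below. What is called first, only, known or untested is meant among the compounds shown, and "the series" means these compounds.

Measured so far:
- compound 1, `Cn1c(-c2ccc(NC(=O)CCl)cc2)nc(-c2ccccc2)c1-c1ccccc1`: 70%
- compound 2, `Cc1ccc2oc(SCC(=O)Nc3ccc(-c4nc(-c5ccccc5)c(-c5ccccc5)n4C)cc3)nc2c1`: 65.1%
- compound 3, `Cn1cnnc1SCC(=O)Nc1ccc(-c2nc(-c3ccccc3)c(-c3ccccc3)n2C)cc1`: 89.3%

In a functional assay on MCF7 cells (Homo sapiens) for cytotoxicity, read by MTT assay, with a stated time of 24 h, tested at 80 ug/mL (a higher number here means a stronger effect of the compound at the concentration tested, a lower number a weaker effect), compound 3 stands highest of the three, with compound 1 nearest and compound 2 furthest. The step of a number 24.2 percentage points higher from compound 2 to compound 3 (beyond the scatter) shows that swapping the group on the sulfur matters, and a number 19.3 percentage points higher from compound 1 to compound 3 (beyond the scatter) points the same way. Compound 4, `Cn1nnnc1SCC(=O)Nc1ccc(-c2nc(-c3ccccc3)c(-c3ccccc3)n2C)cc1`, differs from compound 3 by a small change: 1-methyl-1H-tetrazol-5-yl in place of 4-methyl-4H-1,2,4-triazol-3-yl on a sulfur. The two groups are of the same size and shape, so no step beyond the scatter is expected in this assay; a slight drop is allowed for, since compound 3 sits near the top of the range. Compound 4 is therefore expected to give about 84%, between 65% and 96%, a step of a number 5.3 percentage points lower from compound 3 to compound 4 (within the scatter).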

Compound 4, a percentage reported as activity, at one concentration (the size of the read-out at that concentration, not a potency): 77.7%
Compound 4: middle estimate off by 6.3 percentage points, on the high side; the measured number falls inside the stated range.
By their numbers in this assay, from the lowest: compounds 2, 1 and 4 (each within the scatter of the next, the first and the last beyond it); then compound 3.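

In this assay the group on the sulfur still matters when two five-membered aromatic rings with 6 heavy atoms each are exchanged: the 1-methyl-1H-tetrazol-5-yl group in place of 4-methyl-4H-1,2,4-triazol-3-yl gives a number 11.6 percentage points lower from compound 3 to compound 4 (beyond the scatter) as the result. The same tetrazole group also separates from the 5-methyl-1,3-benzoxazol-2-yl group, with a number 12.6 percentage points higher from compound 2 to compound 4 (beyond the scatter) on that swap, yet a number 7.7 percentage points higher from compound 1 to compound 4 (within the scatter) shows no real separation from the chloro compound. No measurement here explains these differences.

The compounds shown leave open how an amine on the saturated chain carbon would read in this assay in place of these sulfanyl groups. On these data alone, a longer chain between the sulfur and the carbonyl also remains open.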